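Changing the Ring Substituent in a Shared Core

The source may hold more compounds than are shown below. What is called first, only, known or untested is meant among the compounds shown, and "the series" means these compounds.

compound 1 `O=C(CCCCCc1cccc(Br)c1)N1CCOC1=O`: 430 nM
compound 2 `NC(=O)c1cccc(CCCCCC(=O)N2CCOC2=O)c1`: > 20000 nM

In an assay on HEK293 cells for inhibition of N-acylethanolamine-hydrolyzing acid amidase (Rattus norvegicus), read by LC-MS, with a stated time of 30 min (on this read-out higher numbers stand for weaker inhibition and lower numbers for stronger inhibition), compound 1 gives 430 nM. For compound 2 the value > 20000 nM is a limit of the assay and not a number; this is the limit of > 20000 nM in this assay, at which 1 of the 2 values shown sits. Compound 2 thus sits at the weak end of what is shown, and the step of an at least 46-fold higher number from compound 1 to compound 2 (1.66 log units; beyond the scatter) marks a large loss. Compound 3 `Nc1cccc(CCCCCC(=O)N2CCOC2=O)c1` differs from compound 2 by amino in place of carbamoyl on an aromatic carbon, on an aromatic carbon meta to a large group. Among the compounds with values here, no measured step covers this exact change; the one measured step, an at least 46-fold higher number from compound 1 to compound 2 (1.66 log units; beyond the scatter), shows only how far a change at this position has already moved the number. Little movement from compound 2 is expected, so compound 3 is expected to show an at least 1.3-fold lower number from compound 2 to compound 3 (0.12 log units; that floor lies within the scatter). The estimate for compound 3 is 15000 nM, expected to lie between 3000 nM and 60000 nM.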

Compound 3, half-maximal inhibitory concentration: > 20000 nM
Compound 3 gave a limit, no number; the forecaster's own chance of this, stated with the estimate: 50%; at least 1.3-fold (0.12 log units) between middle value and limit.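

Compound 3, like compound 2, stops at a limit of the assay and not a number: the limit of > 20000 nM in this assay, at which 2 of the 3 values shown sit. Amino in place of bromo therefore also brings a large loss, not only carbamoyl, with an at least 46-fold higher number from compound 1 to compound 3 (1.66 log units; beyond the scatter). The step between compound 2 and compound 3 cannot be read, and of the three groups shown only bromo leaves a number.

On these data alone, whether a group such as chloro, methyl or methoxy at this place on the ring would keep a readable number stays open. So does how far any of them would sit from compound 1.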